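This account rests on a few compounds, and the source may have more. Where it says the series, first, only, none or still open, it means among the compounds named here.

Compound 1 `COc1cc2c(cc1OC)CN(S(=O)(=O)c1ccc(-n3cc(COc4ccccc4C(C)=O)nn3)cc1)CC2` stands at the edge of what the assay reports: in a functional assay on A549 cells (Homo sapiens) for cytotoxicity, read by MTT assay, with a stated time of 48 h (on this read-out lower numbers stand for stronger inhibition and higher numbers for weaker inhibition), compound 1 gives > 50 ug/mL, which is a limit rather than a number. Compound 2 `Cc1ccc(OCc2cn(-c3ccc(S(=O)(=O)N4CCc5ccccc5C4)cc3)nn2)cc1` likewise returns only a limit, > 50 ug/mL, in this assay. Compound 3 `COc1cc2c(cc1OC)CN(S(=O)(=O)c1ccc(-n3cc(COc4ccc(C)cc4)nn3)cc1)CC2` also returns a limit, > 50 ug/mL. For the measured compounds named here, the single one-point step available, a step that the two limits leave unreadable from compound 1 to compound 3, cannot be sized because of the limit of > 50 ug/mL in this assay, at which 3 of the 3 values shown sit. Compound 4 `COc1cc2c(cc1OC)CN(S(=O)(=O)c1ccc(-n3cc(COc4ccccc4)nn3)cc1)CC2` differs from compound 1 by hydrogen in place of acetyl on an aromatic carbon. Going by the values given here, no measured step bears on this change, and with every value sitting at the limit, no direction beyond the scatter can be read from the existing data. Compound 4 is therefore expected to remain near the same limit, a step that the limit leaves unreadable from compound 1 to compound 4, with an estimate of 60 ug/mL in a range from 25 ug/mL to 150 ug/mL.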

Compound 4, half-maximal inhibitory concentration: > 50 ug/mL
Compound 4 gave a limit, no number; the forecaster's own chance of this, stated with the estimate: 85%; the middle value lies beyond the limit too.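

The steps to compound 4 from compound 1 and from compound 3 cannot be read: the limit of > 50 ug/mL in this assay, at which 4 of the 4 values shown sit.

The compounds shown leave open whether any group on the phenoxy ring changes the read-out in this assay.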